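A few compounds are considered here, and "the series" means these few. Any claim that something is new, unique, unknown or untested is made for them only; others in the source may bear on it.

Measured compounds in an ADME assay on SH-SY5Y cells (Homo sapiens) for cytotoxicity, read by MTT assay, with a stated time of 48 h; on this read-out higher numbers stand for weaker inhibition and lower numbers for stronger inhibition:
compound 1 `COc1ccc(C(=O)/C=C/c2cc(OC)c(OC)c(OC)c2)c(O)c1` gives only a limit, > 100000 nM
compound 2 `COc1ccc(C(=O)/C=C/c2ccc(C(=O)N3CCCCC3)cc2)c(O)c1` gives only a limit, > 100000 nM
compound 3 `COc1ccc(C(=O)/C=C/c2cc(Br)c(OCc3ccccc3)c(OC)c2)c(O)c1` gives only a limit, > 100000 nM

Compound 2 stands nowhere in particular on these numbers: for compound 2 this assay returns only a limit. Going by the values given here, the same holds across the series, since (the limit of > 100000 nM in this assay, at which 3 of the 3 values shown sit), so no step between measured compounds can be read from the record.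

Compound 4 `COc1ccc(C(=O)/C=C/c2ccc(C(=O)NC(C)C)cc2)c(O)c1` is the next member to be tested. The change from compound 2 is isopropylamino in place of piperidin-1-yl on a carbonyl carbon. Among the compounds with values here, no measured step in this assay involves this change, and none of the three values shown is a number, so there is nothing to set a step against. The expected step is a step that the limit leaves unreadable from compound 2 to compound 4, nothing beyond the scatter of this assay. Compound 4 is expected at 150000 nM, within a range from 50000 nM to 500000 nM, most probably reported again as a limit rather than a number.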

Compound 4, half-maximal inhibitory concentration: > 100000 nM
Compound 4 gave a limit, no number; the forecaster's own chance of this, stated with the estimate: 85%; the middle value does not contradict the limit.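

Compound 2 and compound 4 both give only a limit, so no step can be read between them: the limit of > 100000 nM in this assay, at which 4 of the 4 values shown sit.

The compounds shown leave open whether isopropylamino and piperidin-1-yl on the carbonyl carbon differ at all in this assay, and whether any member of the series gives a number there.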